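Inverting one stereocentre in an aryl urea

The compounds below may be only part of what the source reports. "The series", "measured", "known", "first", "only" and "open" are said of these compounds alone.

Measured compounds:
compound 1, `C[C@H](NC(=O)Nc1cccc(C(F)(F)F)c1)c1ccccc1`, 92%
compound 2, `C[C@@H](NC(=O)Nc1cccc(I)c1)c1ccccc1`, 73%

In an ADME assay on the whole organism with Oryza sativa as the target, tested at 10 uM (on this read-out lower numbers stand for a stronger effect and higher numbers for a weaker effect at the one concentration tested), compound 2 gives the lowest of the two numbers; its nearest neighbour is compound 1, whose value in this assay is higher by a step beyond the scatter. Compound 3, `C[C@H](NC(=O)Nc1cccc(I)c1)c1ccccc1`, is not yet measured. Compared with compound 2, (the two compounds have the same atoms and bonds and differ only in configuration as drawn: 1 of 1 stereo elements differ; a stereocentre at a saturated chain carbon is drawn R in compound 2 and S in compound 3). For the measured compounds named here, no measured pair shows what such an inversion does here, so the expected step from compound 2 to compound 3 in this assay is small, in either direction, and may stay within the scatter, estimated as a number 7 percentage points higher from compound 2 to compound 3 (within the scatter). Compound 3 is expected to give 80% in this assay, within 60% to 97%.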

Compound 3, a percentage reported as activity, at one concentration (the size of the read-out at that concentration, not a potency): 93%
For compound 3 the middle estimate is 13 percentage points below the measured one; low and high end bracket the measured number.
By their numbers in this assay, from the lowest: compound 2; then compounds 1 and 3 (each within the scatter of the next).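

In this assay, the configuration at the saturated chain carbon matters for the iodo compounds, with a number 20 percentage points higher from compound 2 to compound 3 (beyond the scatter). This step can be assigned to configuration alone: the fact that compounds 2 and 3 differ only in the configuration as drawn. With the configuration drawn as in compound 1, iodo in place of trifluoromethyl gives a number 1 percentage points higher from compound 1 to compound 3 (within the scatter), so the two groups cannot be told apart on this read-out.

On these data alone, whether inverting the trifluoromethyl compound would give a similar step remains open. So does how an amine or a carboxylic acid in place of iodo would read in either configuration.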